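Amino in place of cyano: growth inhibition notes

The compounds below may be only part of what the source reports. "The series", "measured", "known", "first", "only" and "open" are said of these compounds alone.

compound 1 `COC(=O)c1sc2cc(-c3cnc(OC)nc3OC)cnc2c1N`: > 75000 nM
compound 2 `COC(=O)c1sc2cc(-c3ccc(C#N)cc3)cnc2c1N`: > 75000 nM

In a functional assay on NCI-H460 cells (Homo sapiens) for inhibition, read by sulforhodamine B assay, with a stated time of 48 h (on this read-out lower numbers stand for stronger inhibition of growth and higher numbers for weaker inhibition of growth), compound 1 gives > 75000 nM, a limit rather than a number. In this assay compound 2 gives > 75000 nM, likewise a limit. Compound 2 therefore stands at the limit of > 75000 nM in this assay, at which 2 of the 2 values shown sit, and no measured number sits anywhere in this set. Compound 3 `COC(=O)c1sc2cc(-c3ccc(N)cc3)cnc2c1N` differs from compound 2 by amino in place of cyano on an aromatic carbon. With compound 2 already at the limit, no step beyond the scatter is expected in either direction. Compound 3 is expected to give 80000 nM, with a range from 20000 nM to 300000 nM, which corresponds to an expected step that the limit leaves unreadable from compound 2 to compound 3.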

Compound 3, concentration for 50% growth inhibition: 37100 nM
The estimate for compound 3 lay 2.2-fold (0.33 log units) above the measured number; the measured number falls inside the stated range.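

In this assay, among the compounds shown here, compound 3 gives 37100 nM, the first measured number in this set rather than a limit. Amino in place of cyano on an aromatic carbon, para to a large group, brings an at least 2.0-fold lower number from compound 2 to compound 3 (0.30 log units; that floor lies within the scatter). The real size of that step stays unread because compound 2 sits at a limit: the limit of > 75000 nM in this assay, at which 2 of the 3 values shown sit.

From the compounds shown here alone, whether the number depends on amino specifically stays open. A hydroxyl, a dimethylamino or an acetamide at this same position would show how far the change reaches.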